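Notes on the step from compound 3 to compound 4

The source may report more compounds than this note shows. Statements on the series, on what has been measured and on what is new or still open speak of the compounds shown alone.

compound 1 `COc1cccc(CNC(=O)N2C(=O)c3ccccc3S2(=O)=O)c1`: 0.523 h
compound 2 `O=C(NCc1ccccc1Cl)N1C(=O)c2ccccc2S1(=O)=O`: 0.42 h
compound 3 `O=C(NCC1CCCCC1)N1C(=O)c2ccccc2S1(=O)=O`: 0.963 h

All three values come from a physicochemical assay for pharmacokinetics; a lower number here means that the compound disappears faster, a higher number that the compound lasts longer. In this assay compound 3 gives 0.963 h. Its standing rests on two steps: a 2.3-fold higher number from compound 2 to compound 3 (0.36 log units; beyond the scatter), and a 1.8-fold higher number from compound 1 to compound 3 (0.27 log units; within the scatter). Only the first of these separates the two values.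

Compound 4 `O=C(NCc1ccc(Br)cc1)N1C(=O)c2ccccc2S1(=O)=O` is not yet measured. The change is 4-bromophenyl in place of cyclohexyl on a saturated chain carbon bound to an amide-type nitrogen.

The same two steps bear on it, read in reverse, since each links cyclohexyl with an aromatic group. The two aromatic groups themselves show only a 1.2-fold lower number from compound 1 to compound 2 (0.10 log units; within the scatter). Among the compounds with values here, no measured compound carries bromine, so this transfer is untested. A drop of similar size is therefore expected, close to the edge of the scatter. The expected step is a 1.9-fold lower number from compound 3 to compound 4 (0.28 log units; within the scatter). The estimated value for compound 4 is 0.5 h, with an expected range of 0.3 h to 0.85 h.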

Compound 4, half-life: 0.187 h
Estimate against measurement, compound 4: 2.7-fold (0.43 log units) above; measured number below the stated range.
By their numbers in this assay, from the lowest: compound 4; then compounds 2, 1 and 3 (each within the scatter of the next, the first and the last beyond it).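

In this assay the change from cyclohexyl to 4-bromophenyl gives a 5.1-fold lower number from compound 3 to compound 4 (0.71 log units; beyond the scatter) and is the largest step yet at this position. The aromatic groups also no longer read as one set: 4-bromophenyl gives a 2.2-fold lower number from compound 2 to compound 4 (0.35 log units; beyond the scatter) and a 2.8-fold lower number from compound 1 to compound 4 (0.45 log units; beyond the scatter) so the choice of aromatic group matters here, which compound 1 and compound 2 alone, within the scatter of each other, did not show. No measurement bears on what lies behind these steps.

Open, going by these compounds, is whether the lower number follows the bromine or the substituted aromatic ring as a whole: a plain phenyl or a 4-chlorophenyl group would separate the two. On these data alone, how this assay responds to an amine or a carboxylic acid at this place also stays open.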